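Removing the Methyl from the Methoxy of Compound 3

The source may hold more compounds than are shown below. What is called first, only, known or untested is meant among the compounds shown, and "the series" means these compounds.

Compound 1 `CC(C)Cc1nc(N)c2nn(-c3ccccc3)cc2n1` gives 13% in an assay on CHO cells for displacement of a labelled ligand from adenosine receptor A3 (Homo sapiens), read by scintillation counting, tested at 1 uM; a higher number here means more inhibition at the concentration tested (going by the name of the read-out), a lower number less inhibition.
Compound 2 `Nc1nc(CCc2ccccc2)nc2cn(-c3ccccc3)nc12` gives 17% in this assay.
Compound 3 `COc1ccc(CCc2nc(N)c3nn(-c4ccccc4)cc3n2)cc1` gives 22% in this assay.

Compound 3 holds the highest of the three numbers, but its margin over compound 2 and over compound 1 lies within the scatter, so the three compounds cannot be ranked on these measurements.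

Compound 4 `Nc1nc(CCc2ccc(O)cc2)nc2cn(-c3ccccc3)nc12` differs from compound 3 by hydrogen in place of methyl on an oxygen on an aromatic ring; cut one bond further out, the change reads methoxy to hydroxy, or 4-methoxyphenyl to 4-hydroxyphenyl. The step that bears most directly on this change is a number 5 percentage points higher from compound 2 to compound 3 (within the scatter), where the methoxy was introduced on the same aromatic carbon. The step of a number 4 percentage points higher from compound 1 to compound 2 (within the scatter) touches a different part of the molecule and was likewise within the scatter. Changes at this end of the molecule have so far not moved the number in this assay beyond the scatter, so no step beyond the scatter is expected here either.

Compound 4 is therefore expected to give about 20% in this assay, within a range from 8% to 32%, which means an expected step of a number 2 percentage points lower from compound 3 to compound 4 (within the scatter) that falls within the scatter.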

Compound 4, a percentage reported as inhibition, at one concentration (the size of the read-out at that concentration, not a potency): 37%
Beside the measured number, compound 4's estimate is 17 percentage points below it; measured number outside the range, above it.
By their numbers in this assay, from the lowest: compounds 1, 2 and 3 (each within the scatter of the next); then compound 4.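

In this assay, the aromatic carbon at the end of the chain now yields steps beyond the scatter: methoxy to hydroxy gives a number 15 percentage points higher from compound 3 to compound 4 (beyond the scatter), and hydroxy in place of hydrogen gives a number 20 percentage points higher from compound 2 to compound 4 (beyond the scatter), whereas methoxy in place of hydrogen gave only a number 5 percentage points higher from compound 2 to compound 3 (within the scatter). Starting from the isopropyl, the 4-hydroxybenzyl group gives a number 24 percentage points higher from compound 1 to compound 4 (beyond the scatter), while benzyl alone gave a number 4 percentage points higher from compound 1 to compound 2 (within the scatter), so among these four compounds the larger number appears only with the hydroxy. Nothing shown here accounts for this difference.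

The compounds shown leave open whether another group on this aromatic carbon, such as an amine or a carboxylic acid, would match the hydroxy. They also leave open whether a longer chain carrying the same 4-hydroxyphenyl would hold the number of compound 4 at 37%.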